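Aryl swaps on the shared core: compound 3 to compound 4

A few compounds are considered here, and "the series" means these few. Any claim that something is new, unique, unknown or untested is made for them only; others in the source may bear on it.

Values in a functional assay on DU-145 cells (Homo sapiens) for inhibition, read by trypan blue exclusion, with a stated time of 96 h; on this read-out higher numbers stand for weaker inhibition of growth and lower numbers for stronger inhibition of growth:
- compound 1 `O=C(/C(=C\c1ccc(Br)cc1)S(=O)(=O)c1ccc(Br)cc1)c1ccc(Br)cc1`: 10000 nM
- compound 2 `O=C(/C(=C\c1ccc(Cl)cc1Cl)S(=O)(=O)c1ccc(Br)cc1)c1ccc(Br)cc1`: 10000 nM
- compound 3 `O=C(/C(=C\c1ccc(F)cc1F)S(=O)(=O)c1ccc(Br)cc1)c1ccc(Br)cc1`: 7500 nM

In this assay compound 3 is not separated from the other two compounds, as a 1.3-fold lower number from compound 1 to compound 3 (0.12 log units; within the scatter) and a 1.3-fold lower number from compound 2 to compound 3 (0.12 log units; within the scatter) show. Compound 1 and compound 2 are likewise not separated, with no change at the digits printed from compound 1 to compound 2 (within the scatter).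

Compound 4 `O=C(/C(=C\c1ccc(Br)c([N+](=O)[O-])c1)S(=O)(=O)c1ccc(Br)cc1)c1ccc(Br)cc1` has 4-bromo-3-nitrophenyl in place of 2,4-difluorophenyl on a double-bonded chain carbon bound to a double-bonded chain carbon.

All three measured steps change this same place, and none lies beyond the scatter. Among the compounds with values here, they are the only guide available, since no measured compound carries the entering group, and the range is kept wide for that reason. No step beyond the scatter is therefore expected, and no direction can be assigned with confidence. The expected step is a 1.1-fold higher number from compound 3 to compound 4 (0.03 log units; within the scatter). For compound 4 the estimated value is 8000 nM, with an expected range from 3000 nM to 16000 nM.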

Compound 4, concentration for 50% growth inhibition: 10000 nM
Compound 4: the middle estimate sits 1.3-fold (0.10 log units) below what was measured; low and high end bracket the measured number.
By their numbers in this assay, from the lowest: compounds 3, 1, 2 and 4 (each within the scatter of the next).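

In this assay, 4-bromo-3-nitrophenyl on a double-bonded chain carbon bound to a double-bonded chain carbon is not separated from 2,4-difluorophenyl (a 1.3-fold higher number from compound 3 to compound 4 (0.12 log units; within the scatter)) or from 2,4-dichlorophenyl (no change at the digits printed from compound 2 to compound 4 (within the scatter)). The series now also holds a change of nitro in place of hydrogen on an aromatic carbon, and this too leaves the read-out unseparated (no change at the digits printed from compound 1 to compound 4 (within the scatter)), so hydrogen-bond acceptors on this aryl group bring no visible shift across the compounds shown. No measurement at hand accounts for this flat response.

Going by these compounds, whether an amine or a carboxylic acid on this aryl group would move the number beyond the scatter remains open. So does the effect of replacing either of the other two 4-bromophenyl groups, which are common to all four compounds.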